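The source may hold more compounds than are shown below. What is called first, only, known or untested is meant among the compounds shown, and "the series" means these compounds.

Compound 1 `C[C@]1(CO)NC[C@@H](O)[C@@H]1O` was tested in an assay on isolated protein for inhibition of tissue alpha-L-fucosidase (Bos taurus), tested at 1000 uM (a lower number here means less inhibition, a higher number more inhibition at the concentration tested (going by the name of the read-out)), and gave 10.9%. Compound 2 `OC[C@@]1(c2cccc(F)c2)NC[C@@H](O)[C@@H]1O` gave 0% in this assay, and compound 3 `OC[C@]1(c2c(F)c(F)c(F)c(F)c2F)NC[C@H](O)[C@H]1O` gave 0%. Compound 3 therefore stands level with compound 2 at the digits recorded, and the two together are the lowest of the three numbers; the nearest neighbour of compound 3 is compound 2, with no change within the scatter, while the furthest is compound 1, whose number lies higher by an amount beyond the scatter.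

Compound 4 `OC[C@@]1(c2c(F)c(F)c(F)c(F)c2F)NC[C@@H](O)[C@@H]1O` is the next compound to be measured in this assay. Its relation to compound 3 is this: the two compounds have the same atoms and bonds and differ only in configuration as drawn: 3 of 3 stereo elements differ (all stereocentres are inverted: mirror images); a stereocentre at a saturated ring carbon is drawn S in compound 3 and R in compound 4; a stereocentre at a saturated ring carbon is drawn S in compound 3 and R in compound 4; a stereocentre at a saturated ring carbon is drawn S in compound 3 and R in compound 4. For the measured compounds named here, no pair of already measured compounds shows what such a change does here, and compound 4 shares the drawn configuration of its three ring stereocentres with compound 2, which gave 0%, so little movement is expected. The step from compound 3 to compound 4 is expected to be a number 3 percentage points higher from compound 3 to compound 4 (within the scatter), within the scatter. Compound 4 is estimated at 3%, in a range from 0% to 15%.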

Compound 4, a percentage reported as inhibition, at one concentration (the size of the read-out at that concentration, not a potency): 3.8%
The estimate for compound 4 lay 0.8 percentage points below the measured number; measured number inside the range.
By their numbers in this assay, from the lowest: compounds 2, 3, 4 and 1 (each within the scatter of the next, the first and the last beyond it).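

For the compounds shown here, this pair is the first here to change configuration alone, and in this assay the full inversion of the three ring stereocentres gives a number 3.8 percentage points higher from compound 3 to compound 4 (within the scatter). With this aryl group in place, the assay therefore does not tell the two mirror images apart at the single concentration tested. The comparison isolates stereochemistry, with no change of substituent to confound it: the fact that compounds 3 and 4 differ only in the configuration as drawn.

The compounds shown leave open whether the same inversion would also make no clear difference with the methyl group of compound 1 at this ring carbon, or at a concentration other than the one tested. They also leave open how the mirror-image pair would read out with an aminomethyl group or a carboxylic acid at that carbon.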